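Swapping a Dichlorophenyl for a Bromophenyl on Two Cores

This account rests on a few compounds, and the source may have more. Where it says the series, first, only, none or still open, it means among the compounds named here.

Of the compounds shown here, three have been tested in a functional assay on KB3 cells (Homo sapiens) for antiproliferative activity, read by MTT assay, with a stated time of 96 h; a lower number here means a stronger inhibitor, a higher number a weaker inhibitor. Compound 1 `C=C(C)[C@H]1CC(=O)C(C)=C2[C@@H](C(=O)OCC)O[C@@H](c3cccc(Br)c3)[C@@H]21` gives 30000 nM. Compound 2 `C=C(C)[C@H]1CC(=O)C(C)=C2[C@@H](C(=O)OCC)O[C@@H](c3cccc(Cl)c3Cl)[C@@H]21` gives 5000 nM. Compound 3 `C=C(C)[C@H]1CC=C(C)[C@@]2(O)[C@@H]1[C@H](c1cccc(Cl)c1Cl)O[C@@H]2C(=O)OCC` gives 5000 nM. Compound 2 and compound 3 sit level at the digits shown; how their two cores differ is not broken down here.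

Between compound 2 and compound 1 a single change is made: 3-bromophenyl in place of 2,3-dichlorophenyl on a saturated ring carbon. It produced a 6.0-fold higher number from compound 2 to compound 1 (0.78 log units; beyond the scatter), a modest weakening that lies beyond the usual scatter.

Compound 4 `C=C(C)[C@H]1CC=C(C)[C@@]2(O)[C@@H]1[C@H](c1cccc(Br)c1)O[C@@H]2C(=O)OCC` has not yet been measured. It differs from compound 3 by 3-bromophenyl in place of 2,3-dichlorophenyl on a saturated ring carbon. Within the data shown here, this is the same kind of change as the one from compound 2 to compound 1, though the surroundings are not identical: on the core of compound 3 the place is also two ring bonds from the ring atom that bears a hydroxy group, which the core of compound 2 does not carry.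

Compound 4 is expected to land near 25000 nM, with a likely range from 10000 nM to 60000 nM. The expected step of a 5.0-fold higher number from compound 3 to compound 4 (0.70 log units; beyond the scatter) rests on the earlier outcome because a 6.0-fold higher number from compound 2 to compound 1 (0.78 log units; beyond the scatter) was seen with the same kind of change, widened a little for the difference in the two cores. The actual reading for compound 4 follows.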

Compound 4, half-maximal inhibitory concentration: 3000 nM
For compound 4 the middle estimate is 8.3-fold (0.92 log units) above the measured one; the whole stated range lies above it.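

In this assay, the change from 2,3-dichlorophenyl to 3-bromophenyl on the core of compound 3 gives a 1.7-fold lower number from compound 3 to compound 4 (0.22 log units; within the scatter), so on this core the two readings cannot be told apart. Set beside the earlier step, the same swap on a saturated ring carbon does not carry over unchanged from one core to the other in this series: the same change on two cores in this assay, a 6.0-fold higher number (0.78 log units; beyond the scatter) from compound 2 to compound 1 and a 1.7-fold lower number (0.22 log units; within the scatter) from compound 3 to compound 4, 10-fold (1.00 log units) apart, beyond the scatter of two such steps. Among these compounds, with only one pair on each core, this shows that a step seen on one core is a poor guide to the step on the other, but it does not show which difference between the cores is responsible or whether the gap would hold for any other pair of groups.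

The compounds shown leave open whether the hydroxy group, which the core of compound 3 carries and the core of compound 2 does not, accounts for the gap, since the two cores differ in more than that one group. They also leave open how each core would respond to a phenyl ring bearing an amine or a carboxylic acid on that same ring carbon, as only halogen-bearing phenyl rings appear there.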